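Ring Nitrogen Enters the Amide Aryl Group

The compounds below may be only part of what the source reports. "The series", "measured", "known", "first", "only" and "open" are said of these compounds alone.

Measured so far in a functional assay on HEK293 cells for agonist activity at probable G-protein coupled receptor 27 (Homo sapiens), read by a luciferase reporter and beta-arrestin recruitment, with a stated time of 10 min; on this read-out higher numbers stand for larger maximal responses and lower numbers for smaller maximal responses:
compound 1 `N#Cc1ccc(C(=O)Nc2ccc(S(=O)(=O)Nc3ccccc3)cc2)c(F)c1` gives 29%
compound 2 `O=C(Nc1ccc(S(=O)(=O)Nc2ccccc2)cc1)c1ccc(Cl)cc1Br` gives 123%
compound 3 `O=C(Nc1ccc(S(=O)(=O)Nc2ccccc2)cc1)c1ccc(Cl)cc1F` gives 57%

Compound 3 stands second of the three numbers: the step of a number 28 percentage points higher from compound 1 to compound 3 (beyond the scatter) puts it above compound 1, and the step of a number 66 percentage points lower from compound 2 to compound 3 (beyond the scatter) puts it well below compound 2. Compound 4 `O=C(Nc1ccc(S(=O)(=O)Nc2ccccc2)cc1)c1ccc(Cl)nc1F` keeps the shared core and alters only the group on the carbonyl carbon: 6-chloro-2-fluoropyridin-3-yl in place of 4-chloro-2-fluorophenyl on a carbonyl carbon. Among the compounds with values here, the measured steps show that changes on this ring can move the maximal response a great deal, as in a number 94 percentage points higher from compound 1 to compound 2 (beyond the scatter), but each of them swaps a halogen or a nitrile; none puts a nitrogen into the ring itself, so no measured step bears directly on this change. In this assay compound 4 is therefore expected to stay near compound 3, with an expected step of a number 7 percentage points lower from compound 3 to compound 4 (within the scatter) and a wide range. The estimate for compound 4 is 50%, expected to fall between 20% and 85%.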

Compound 4, largest response reached (Emax), in percent of the reference or control that the assay uses: 78%
Compound 4: the middle estimate sits 28 percentage points below what was measured, and the stated range covers the measured number.
By their numbers in this assay, from the lowest: compound 1; then compound 3; then compound 4; then compound 2.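

In this assay, exchanging one ring carbon for a nitrogen while keeping both halogens gives a real rise (a number 21 percentage points higher from compound 3 to compound 4 (beyond the scatter)), so the ring atoms at this place on the carbonyl carbon matter as well as the groups they carry. The 6-chloro-2-fluoropyridin-3-yl group still falls short of the 2-bromo-4-chlorophenyl group (a number 45 percentage points lower from compound 2 to compound 4 (beyond the scatter)) but clearly exceeds the 4-cyano-2-fluorophenyl group (a number 49 percentage points higher from compound 1 to compound 4 (beyond the scatter)). No measurement at hand explains why the ring nitrogen raises the maximal response.

The compounds shown leave open whether bromo in place of fluoro would also raise the response on the pyridine ring, as it does on the phenyl ring. They also leave open how a methoxy group or an amine in place of the chloro would behave on this ring.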